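A few compounds are considered here, and "the series" means these few. Any claim that something is new, unique, unknown or untested is made for them only; others in the source may bear on it.

In a functional assay on Jurkat cells (Homo sapiens) for antiproliferative activity, read by MTT assay, with a stated time of 72 h (a higher number here means a weaker inhibitor, a lower number a stronger inhibitor), compound 1 `CCOc1ccc(-c2sc(NC)nc2-c2cc(OC)c(OC)c(OC)c2)cc1` gives 1.7 nM, whereas compound 2 `COc1cc(-c2nc(N(C)C)sc2-c2ccc(C)cc2)cc(OC)c1OC` gives 6660 nM. Compound 3 `COc1ccc(-c2sc(N(C)C)nc2-c2cc(OC)c(OC)c(OC)c2)cc1` gives 7600 nM, which is level with compound 2 within the scatter and a far higher number than that of compound 1. Compound 4 `CCOc1ccc(-c2sc(N(C)C)nc2-c2cc(OC)c(OC)c(OC)c2)cc1` differs from compound 3 by methyl in place of hydrogen on a saturated chain carbon bound to an oxygen on an aromatic ring, so that methoxy becomes ethoxy and 4-methoxyphenyl becomes 4-ethoxyphenyl. For the measured compounds named here, only one measured step touches this place: a 1.1-fold higher number from compound 2 to compound 3 (0.06 log units; within the scatter), with methoxy in place of methyl on an aromatic carbon, and it stays within the scatter. Compound 1 also carries 4-ethoxyphenyl, but it has methylamino where compound 4 has dimethylamino, so the data cannot separate these two changes. The step of a 1.9-fold lower number from compound 3 to compound 4 (0.28 log units; within the scatter) is therefore expected to be small, leaning slightly towards a lower number and of about the size of the scatter. For compound 4 the estimated value is 4000 nM, with an expected range of 800 nM to 15000 nM.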

Compound 4, half-maximal inhibitory concentration: 4150 nM
For compound 4 the middle estimate is 1.0-fold (0.02 log units) below the measured one, and the stated range covers the measured number.
By their numbers in this assay, from the lowest: compound 1; then compounds 4, 2 and 3 (each within the scatter of the next).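

In this assay, with dimethylamino in place, ethoxy and methoxy cannot be told apart on this aromatic ring (a 1.8-fold lower number from compound 3 to compound 4 (0.26 log units; within the scatter)), and ethoxy and methyl cannot either (a 1.6-fold lower number from compound 2 to compound 4 (0.21 log units; within the scatter)), so compound 2, compound 3 and compound 4 stand level. Compound 1 alone could not show what its ethoxy group contributed, but with 4-ethoxyphenyl now held constant, the large gap (a 2400-fold higher number from compound 1 to compound 4 (3.39 log units; beyond the scatter)) goes with methyl in place of hydrogen on a nitrogen on an aromatic ring. The ethoxy group therefore does not carry this gap.

The compounds shown leave open whether a longer chain such as propoxy would stay level here, and whether methylamino compounds with methoxy or methyl at this place would match compound 1. Nothing measured here gives a reason for the large gap.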